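A few compounds are considered here, and "the series" means these few. Any claim that something is new, unique, unknown or untested is made for them only; others in the source may bear on it.

The series is followed in a functional assay on HT-29 cells (Homo sapiens) for cytotoxicity, read by sulforhodamine B assay, with a stated time of 48 h, tested at 10 uM; on this read-out higher numbers stand for a weaker effect at the one concentration tested and lower numbers for a stronger effect. Within the data shown here, compound 1 `COc1cc(C)cc(-c2c(-c3ccnc(-c4ccc(N(C)C)cc4)c3)cnn2CC#N)c1` gives -48% in this assay, the second highest of the three numbers measured so far. Compound 2 `Cc1cc(O)cc(-c2nn(CC#N)cc2-c2ccnc(-c3ccc(Oc4ccccc4)cc3)c2)c1` gives -89%, a number lower than that of compound 1 by more than the usual scatter, and thus a stronger effect. Compound 3 `COc1cc(C)cc(-c2nn(CC#N)cc2-c2ccc(-c3cccc(C(C)=O)c3)nc2)c1` gives -11%, higher than compound 1 by more than the scatter, and is the nearest of the three to compound 1. Compound 4 `COc1cc(C)cc(-c2c(-c3ccnc(-c4ccc(C(C)=O)cc4)c3)cnn2CC#N)c1` has not yet been measured. It differs from compound 1 in one place: acetyl in place of dimethylamino on an aromatic carbon; the change sits on an aromatic carbon of a six-membered aromatic ring of carbon only, para to a large group, and read one bond further out it is 4-(dimethylamino)phenyl to 4-acetylphenyl. Among the measured compounds shown here, no step between two measured compounds carries this same change, so the size of the step is open. Compound 3 also carries an acetyl and gives -11%. On that basis the expected step, a number 18 percentage points higher from compound 1 to compound 4 (beyond the scatter), is of about the scatter or somewhat beyond it, toward a weaker effect, with wide uncertainty. For compound 4 the value in this assay is estimated at -30%, within -60% to 0%.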

Compound 4, a percentage reported as activity, at one concentration (the size of the read-out at that concentration, not a potency): 6%
For compound 4 the middle estimate is 36 percentage points below the measured one, outside the stated range (above it).
By their numbers in this assay, from the lowest: compound 2; then compound 1; then compound 3; then compound 4.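

In this assay, among these compounds, the exchange of 4-(dimethylamino)phenyl for 4-acetylphenyl gives a number 54 percentage points higher from compound 1 to compound 4 (beyond the scatter) and so provides the first direct reading at this position, a large step toward a weaker effect. This aromatic carbon, para to a large group, is therefore not indifferent to the group it carries, although dimethylamino and acetyl match in heavy atoms, hydrogen-bond donors, hydrogen-bond acceptors and net charge as counted here. Nothing at hand bears on the reason for a step of this size.

With only this one step at the position, the compounds shown leave open whether the change follows from losing dimethylamino or from gaining acetyl. From the compounds shown here alone, a primary amine or a carboxylic acid on the same carbon would help separate these two readings, and it also remains open whether the same exchange carries over to other cores.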